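The source may report more compounds than this note shows. Statements on the series, on what has been measured and on what is new or still open speak of the compounds shown alone.

Measured compounds in an assay on HEK293 cells for activation of Kir3.1/Kir3.2 (Homo sapiens), read by thallium flux; on this read-out higher numbers stand for an effect only at larger amounts of compound and lower numbers for an effect already at smaller amounts:
- Compound 1 `Cc1cc(NC(=O)Cn2nnc(-c3ccccc3)n2)n(C2CCC(F)(F)CC2)n1` gives 84 nM.
- Compound 2 `Cc1nc(-c2ccccc2)c(NC(=O)Cn2nnc(-c3ccccc3)n2)s1` is reported as "not active" (no number reported), without a number.
- Compound 3 `Cc1cc(NC(=O)Cn2nnc(-c3ccccc3F)n2)n(C2CCCCC2)n1` gives 187 nM.

Within these numbers compound 3 stands at the highest of the two values reported. Its nearest neighbour is compound 1, whose value in this assay lies lower by a step that falls beyond the usual scatter. Compound 2 stands apart, since for it no number was obtained in this assay.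

The next compound, compound 4 `Cc1cc(NC(=O)Cn2nnc(C3CC3)n2)n(C2CCCCC2)n1`, is not yet measured. It follows from compound 3 by one change: cyclopropyl in place of 2-fluorophenyl on an aromatic carbon. Among the compounds with numbers, no pair differs in exactly this way, so the size of the step has to be judged from the change itself rather than from a measured counterpart. Every compound that gave a number carries an aromatic ring on that aromatic carbon of the five-membered ring, and compound 4 would be the first without one.

The step from compound 3 to compound 4 in this assay is therefore expected to be an increase, a 3.2-fold higher number from compound 3 to compound 4 (0.51 log units; beyond the scatter), beyond the scatter. For compound 4 the estimated value in this assay is 600 nM, with a range from 150 nM to 3000 nM.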

Compound 4, half-maximal effective concentration: > 3000 nM
Compound 4: a limit, no number; the forecaster's own chance of this, stated with the estimate: 25%; at least 5.0-fold (0.69 log units) between middle value and limit.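

In this assay compound 4 gives > 3000 nM, which is a limit of the assay and not a number. Cyclopropyl in place of 2-fluorophenyl on the aromatic carbon between two ring nitrogen atoms amounts to an at least 16-fold higher number from compound 3 to compound 4 (1.20 log units; beyond the scatter), so this position is far from indifferent to the group it carries, and a three-membered non-aromatic ring of carbon does not stand in for the six-membered aromatic ring here. The earlier compounds shown here could not show this, since both compounds with numbers carry a six-membered aromatic ring at this place, and the new step has a lower bound but no upper one: the limit of > 3000 nM in this assay, at which 1 of the 4 values shown sits.

The compounds shown leave open whether the aromatic ring itself matters at this position or whether size alone counts, a question that a pyridyl ring or a morpholine group at the same place would bear on. They also leave the part played by the fluorine of the 2-fluorophenyl group unsettled, since compound 1 and compound 3 differ in more than one place.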